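Swapping the Purine Substituent: From Cyclohexylsulfanyl to Bromophenyl

The source may report more compounds than this note shows. Statements on the series, on what has been measured and on what is new or still open speak of the compounds shown alone.

Measured compounds:
- Compound 1, `OC[C@H]1O[C@@H](n2cnc3c(SC4CCCCC4)ncnc32)[C@H](O)[C@@H]1O`: 6310 nM
- Compound 2, `CSc1ncnc2c1ncn2C1CCCCO1`: 275000 nM
- Compound 3, `Nc1nc(SCc2cccc(Br)c2)c2ncn([C@@H]3O[C@H](CO)[C@@H](O)[C@H]3O)c2n1`: 2880 nM

All three were tested in an assay on isolated protein for binding affinity to Equilibrative nucleoside transporter 1 (Homo sapiens); on this read-out lower numbers stand for stronger inhibition and higher numbers for weaker inhibition. Among the three numbers, compound 1 holds the second highest. The nearest neighbour is compound 3, whose number is lower and lies beyond the usual scatter; the furthest is compound 2, whose number is far higher, also well beyond the scatter.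

The step considered here leads from compound 1 to the as yet unmeasured compound 4, `OC[C@H]1O[C@@H](n2cnc3c(CSc4ccc(Br)cc4)ncnc32)[C@H](O)[C@@H]1O`. The two differ in one place: ((4-bromophenyl)sulfanyl)methyl in place of cyclohexylsulfanyl on an aromatic carbon. The sulfur-containing side chain on the shared core is thus rebuilt, exchanging a saturated six-membered ring for an aromatic one carrying bromine, with the sulfur now one atom further from the core.

Among the measured compounds shown here, no measured pair reports this particular exchange, so the expectation rests on the three numbers above. Compound 3, which also carries a brominated aromatic ring joined through sulfur, shows a lower number than compound 1, which hints that compound 4 may move in the same direction. The step from compound 1 to compound 4 is expected to be a 1.4-fold lower number from compound 1 to compound 4 (0.15 log units; within the scatter), modest and not clearly beyond the scatter. Compound 4 is therefore estimated at 4500 nM, with a plausible range from 1200 nM to 18000 nM.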

Compound 4, half-maximal inhibitory concentration: 178 nM
Beside the measured number, compound 4's estimate is 25-fold (1.40 log units) above it; measured number outside the range, below it.
By their numbers in this assay, from the lowest: compound 4; then compound 3; then compound 1; then compound 2.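

In this assay, the side chain on this aromatic carbon of the shared core has a strong influence on the read-out: exchanging cyclohexylsulfanyl for ((4-bromophenyl)sulfanyl)methyl gives a 35-fold lower number from compound 1 to compound 4 (1.55 log units; beyond the scatter), a large step well beyond normal repeat variation. Among the compounds shown here, the earlier compounds included no pair differing only in this place, so this is the first direct reading of the position, and it shows that the saturated ring is not required for inhibition and that a brominated aromatic ring in a rebuilt side chain gives much stronger inhibition. The exchange is a bundle of changes, however, with the ring type, the bromine and the distance of the sulfur from the core all altered together, so the step belongs to the whole exchange and not to any one of its parts.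

The data shown offer no explanation for the size of this step. They also leave open which part of the exchange carries the gain, a question that a phenyl ring without bromine, a chlorine in place of the bromine or an amine in place of the sulfur could each help to separate.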